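Chloro in Place of Hydrogen on the Phenyl Ring

The source may report more compounds than this note shows. Statements on the series, on what has been measured and on what is new or still open speak of the compounds shown alone.

Compound 1 `CC1=CC[C@@H]([C@@](C)(O)CCCC(C)(C)NC(=S)N/N=C\c2ccccc2)CC1` is the parent of this small set. In a functional assay on NCI-H460 cells (Homo sapiens) for cytotoxicity, read by sulforhodamine B assay (a higher number here means a weaker inhibitor of growth, a lower number a stronger inhibitor of growth), compound 1 gives only a limit, > 100000 nM, so its own position is not a number. Compound 2 `CC1=CC[C@@H]([C@@](C)(O)CCCC(C)(C)NC(=S)N/N=C\c2ccccc2[N+](=O)[O-])CC1` also returns a limit in this assay, > 100000 nM. For the measured compounds named here, compound 3 `CC1=CC[C@@H]([C@@](C)(O)CCCC(C)(C)NC(=S)N/N=C\c2cccc([N+](=O)[O-])c2)CC1` is the one member with a measured number, 68600 nM in this assay.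

Compound 4 `CC1=CC[C@@H]([C@@](C)(O)CCCC(C)(C)NC(=S)N/N=C\c2ccccc2Cl)CC1` differs from compound 1 by chloro in place of hydrogen on an aromatic carbon. Going by the values given here, two measured steps bear on this change. The step that the two limits leave unreadable from compound 1 to compound 2 places a nitro at the same position and stays unreadable because both values sit at the limit of > 100000 nM in this assay, at which 2 of the 3 values shown sit. The step of an at least 1.4-fold lower number from compound 1 to compound 3 (0.16 log units; that floor lies within the scatter) is the other nitro step, and its floor lies within the scatter. Neither step gives ground to expect the chloro of compound 4 to move the number far from compound 1. The expected step is a number no higher from compound 1 to compound 4 (the limit leaves the size open), most probably leaving compound 4 again at the limit. Compound 4 is therefore estimated at 100000 nM, within 50000 nM to 300000 nM.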

Compound 4, concentration for total growth inhibition: > 100000 nM
Compound 4 ended at the assay's limit (the forecaster's own chance of this, stated with the estimate: 60%); the middle value sits exactly at the limit.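

In this assay the 2-chlorophenyl of compound 4 gives the same reading as the phenyl of compound 1 and the 2-nitrophenyl of compound 2, and the steps among these three cannot be read, since all three values are limits and not numbers: the limit of > 100000 nM in this assay, at which 3 of the 4 values shown sit.

For the compounds shown here, the one readable comparison, an at least 1.4-fold higher number from compound 3 to compound 4 (0.16 log units; that floor lies within the scatter), does not firmly set the 2-chlorophenyl apart from the 3-nitrophenyl. What is new is that chloro, like nitro, leaves this aromatic carbon at the limit, so that reading is not confined to the nitro group.

On these data alone, what compound 1, compound 2 and compound 4 would read as numbers stays open, so hydrogen, nitro and chloro cannot be ranked at this place. Also open, as far as these compounds go, is whether an amine or a carboxylic acid on the phenyl ring would give a measurable number.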